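Pyrrole carboxamide in place of the methylpyrrolylmethyl amine

The source may hold more compounds than are shown below. What is called first, only, known or untested is meant among the compounds shown, and "the series" means these compounds.

The three measured compounds share one core and differ only in the aromatic group on the saturated chain carbon bound to the ring nitrogen: compound 1 `COc1cccc(CNc2ccc(C(=O)N3CCC(N4CCCCC4)CC3)cc2Cl)c1`, compound 2 `Cc1ccc(CNc2ccc(C(=O)N3CCC(N4CCCCC4)CC3)cc2Cl)cc1` and compound 3 `Cn1cccc1CNc1ccc(C(=O)N2CCC(N3CCCCC3)CC2)cc1Cl`. In an assay on HEK293 cells for inhibition of Leucine-rich repeat serine/threonine-protein kinase 2 variant G2019S (Homo sapiens), with a stated time of 15 min (on this read-out lower numbers stand for stronger inhibition and higher numbers for weaker inhibition), compound 1 gives > 1000 nM, which is a limit of the assay and not a number. Compound 2 gives > 1000 nM, also a limit. Compound 3 gives > 1000 nM, again a limit. Accordingly none of the steps among them can be read: a step that the two limits leave unreadable from compound 1 to compound 2, a step that the two limits leave unreadable from compound 1 to compound 3 and a step that the two limits leave unreadable from compound 2 to compound 3 all rest on (the limit of > 1000 nM in this assay, at which 3 of the 3 values shown sit).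

Compound 4 `O=C(Nc1ccc(C(=O)N2CCC(N3CCCCC3)CC2)cc1Cl)c1ccc[nH]1` is not yet measured. Relative to compound 3 it carries (1H-pyrrol-2-yl)carbonyl in place of (1-methyl-1H-pyrrol-2-yl)methyl on a nitrogen on an aromatic ring. Among the compounds with values here, no measured step bears on this change, and the three unreadable steps show only that exchanging aromatic groups on the saturated carbon never brought a compound below the limit. Compound 3 stands at the limit, so the starting point for this step is itself unknown. Compound 4 is therefore expected in this assay near 1500 nM, within 300 nM to 8000 nM. The step from compound 3 to compound 4 is estimated at a step that the limit leaves unreadable from compound 3 to compound 4, with the reservation that it is set against a limit.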

Compound 4, half-maximal inhibitory concentration: > 1000 nM
Compound 4: only a limit was reported (the forecaster's own chance of this, stated with the estimate: 60%); the middle value does not contradict the limit.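

In this assay compound 4 gives > 1000 nM, which is a limit and not a number. Its steps to compound 1, compound 2 and compound 3 therefore cannot be read: the limit of > 1000 nM in this assay, at which 4 of the 4 values shown sit.

The compounds shown leave open how far any of them lies past this limit, and whether any group on the nitrogen gives a readable value in this assay.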